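Moving the chlorine on the benzyl group of compound 3

The source may report more compounds than this note shows. Statements on the series, on what has been measured and on what is new or still open speak of the compounds shown alone.

Compound 1 `Cc1ccc(S(=O)(=O)N(Cc2nnc(Cc3ccc(C(F)(F)F)cc3)o2)c2cccc(Cl)c2C)cc1` gives 50.1 nM in an assay on CHO cells for displacement of a labelled ligand from prostaglandin E2 receptor EP1 subtype (Homo sapiens); a higher number here means a weaker inhibitor, a lower number a stronger inhibitor.
Compound 2 `Cc1ccc(S(=O)(=O)N(Cc2nnc(Cc3cccc(F)c3)o2)c2cccc(Cl)c2C)cc1` gives 316 nM in this assay.
Compound 3 `Cc1ccc(S(=O)(=O)N(Cc2nnc(Cc3ccccc3Cl)o2)c2cccc(Cl)c2C)cc1` gives 79.4 nM in this assay.

Among these three numbers compound 3 holds the second highest. Its distance from compound 1 is small, a 1.6-fold higher number from compound 1 to compound 3 (0.20 log units; within the scatter), so the two cannot be told apart, whereas the gap to compound 2 is clear, a 4.0-fold lower number from compound 2 to compound 3 (0.60 log units; beyond the scatter).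

Compound 4 `Cc1ccc(S(=O)(=O)N(Cc2nnc(Cc3cccc(Cl)c3)o2)c2cccc(Cl)c2C)cc1` differs from compound 3 in one place: 3-chlorophenyl in place of 2-chlorophenyl on a saturated chain carbon bound to an aromatic carbon. Within the data shown here, two measured steps bear on this change. The step of a 4.0-fold lower number from compound 2 to compound 3 (0.60 log units; beyond the scatter) shows that the 2-chlorophenyl of compound 3 gives a clearly lower number than the 3-fluorophenyl of compound 2, and the step of a 6.3-fold higher number from compound 1 to compound 2 (0.80 log units; beyond the scatter) shows that the 3-fluorophenyl also gives a higher number than the 4-(trifluoromethyl)phenyl of compound 1. In both cases the 3-substituted phenyl carries the weakest number in this assay. Chlorine and fluorine are not the same halogen, so the transfer is uncertain, but the only evidence points one way.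

Compound 4 is therefore expected to give a higher number than compound 3, by a modest step of a 2.0-fold higher number from compound 3 to compound 4 (0.30 log units; within the scatter). The estimate for compound 4 in this assay is 160 nM, with a range from 60 nM to 400 nM.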

Compound 4, half-maximal inhibitory concentration: 158 nM
Compound 4: middle estimate off by 1.0-fold (0.01 log units), on the high side, and the stated range covers the measured number.
By their numbers in this assay, from the lowest: compounds 1, 3, 4 and 2 (each within the scatter of the next, the first and the last beyond it).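

Placing the chlorine as 3-chlorophenyl rather than 2-chlorophenyl on the saturated chain carbon bound to an aromatic carbon gives a step that cannot be separated from noise in this assay (a 2.0-fold higher number from compound 3 to compound 4 (0.30 log units; within the scatter)), and the same holds for chloro in place of fluoro on an aromatic carbon (a 2.0-fold lower number from compound 2 to compound 4 (0.30 log units; within the scatter)), so neither the chlorine's position nor this choice of halogen is resolved as mattering here. Among these compounds, what the earlier compounds did not show is that a 3-chlorophenyl can be told apart from the 4-(trifluoromethyl)phenyl (a 3.2-fold higher number from compound 1 to compound 4 (0.50 log units; beyond the scatter)), a separation that the 2-chlorophenyl of compound 3 did not reach against compound 1. Nothing available here accounts for these numbers.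

The compounds shown leave open where an unsubstituted phenyl would fall in this series, and whether a methoxy, a nitrile or an amine on the phenyl ring would stay with the halogen-bearing groups or move clearly away from them. They also leave open whether a longer chain in place of the single saturated carbon would keep numbers of this order.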